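A few compounds are considered here, and "the series" means these few. Any claim that something is new, unique, unknown or untested is made for them only; others in the source may bear on it.

Working notes on the series.

Compound 1 `Cc1cn([C@@H]2O[C@H](CO[Si](C)(C)C(C)(C)C)[C@@]3(OS(=O)(=O)C=C3NCCC(=O)OCc3ccccc3)[C@H]2O[Si](C)(C)C(C)(C)C)c(=O)n(C)c1=O` sits at a limit of a functional assay on MT4 cells (Homo sapiens) (on this read-out higher numbers stand for lower toxicity in this test and lower numbers for higher toxicity in this test), rather than at a number, giving > 250000 nM. Compound 2 `Cc1cn([C@@H]2O[C@H](CO[Si](C)(C)C(C)(C)C)[C@@]3(OS(=O)(=O)C=C3NC(=O)c3ccccc3)[C@H]2O[Si](C)(C)C(C)(C)C)c(=O)n(C)c1=O` gives 4900 nM in this assay, and compound 3 `COC(=O)C(=O)CNC1=CS(=O)(=O)O[C@@]12[C@@H](CO[Si](C)(C)C(C)(C)C)O[C@@H](n1cc(C)c(=O)n(C)c1=O)[C@@H]2O[Si](C)(C)C(C)(C)C` gives 10300 nM in this assay. Among the two numbers compound 3 stands highest; its nearest neighbour is compound 2, with a 2.1-fold higher number from compound 2 to compound 3 (0.32 log units; beyond the scatter). Both numbered compounds lie far from the limit of compound 1: an at least 51-fold lower number from compound 1 to compound 2 (1.70 log units; beyond the scatter) and an at least 24-fold lower number from compound 1 to compound 3 (1.38 log units; beyond the scatter).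

Compound 4 `Cc1cn([C@@H]2O[C@H](CO[Si](C)(C)C(C)(C)C)[C@@]3(OS(=O)(=O)C=C3NCCC(N)=O)[C@H]2O[Si](C)(C)C(C)(C)C)c(=O)n(C)c1=O` is the next member, differing from compound 3 as follows: carbamoylmethyl in place of (methoxycarbonyl)carbonyl on a saturated chain carbon bound to an amine nitrogen. Cut one bond further out, the same difference reads ((methoxycarbonyl)carbonyl)methyl to 2-carbamoylethyl. The step that bears on it is an at least 24-fold lower number from compound 1 to compound 3 (1.38 log units; beyond the scatter), which runs through the same position on the saturated chain carbon bound to the amine nitrogen and was large, with compound 1 sitting at the limit (the limit of > 250000 nM in this assay, at which 1 of the 3 values shown sits). Compound 4 returns to a three-carbon chain on the amine nitrogen, as in compound 1, so a step in this assay toward a higher number is expected, perhaps reaching the limit again. For compound 4 the expected step is a 5.8-fold higher number from compound 3 to compound 4 (0.77 log units; beyond the scatter). Compound 4 is therefore estimated at 60000 nM in this assay, within the range 15000 nM to 250000 nM.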

Compound 4, half-maximal cytotoxic concentration: 20000 nM
Compound 4: the middle estimate sits 3.0-fold (0.48 log units) above what was measured; the range from low to high includes it.
By their numbers in this assay, from the lowest: compound 2; then compounds 3 and 4 (each within the scatter of the next). At a limit, above all of these: compound 1.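

In this assay, replacing (methoxycarbonyl)carbonyl with carbamoylmethyl on the saturated chain carbon bound to the amine nitrogen gives a 1.9-fold higher number from compound 3 to compound 4 (0.29 log units; within the scatter), so this change cannot be separated from the scatter, whereas 2-carbamoylethyl in place of benzoyl on the amine nitrogen gives a 4.1-fold higher number from compound 2 to compound 4 (0.61 log units; beyond the scatter). The new comparison with compound 1 changes only the end of the chain, with amino in place of benzyloxy on a carbonyl carbon, and gives an at least 12-fold lower number from compound 1 to compound 4 (1.09 log units; beyond the scatter), showing that this chain does not stay at the limit once the benzyloxy group is gone. Among these compounds, compound 1 remains the only member given as a limit rather than a number: the limit of > 250000 nM in this assay, at which 1 of the 4 values shown sits.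

On these data alone, it remains open what a carboxylic acid or a methyl ester would give at the same carbonyl carbon, and whether a small alkyl ester would stand with the amide or with the benzyl ester. A longer chain carrying the same carbamoyl end would also be needed to separate the contribution of chain length from that of the end group.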